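Solubility notes on the pyridylmethylamine series

The compounds below may be only part of what the source reports. "The series", "measured", "known", "first", "only" and "open" are said of these compounds alone.

Compound 1 `COc1ccc(-c2cnn3c(NCc4ccccn4)cc(C)nc23)cc1`, compound 2 `Cc1cc(NCc2ccccn2)n2ncc(-c3ccccc3C)c2n1` and compound 3 `Cc1cc(NCc2ccccn2)n2ncc(-c3c(C)cccc3C)c2n1` share one core and differ only in the aryl group carried on the five-membered ring. In a physicochemical assay for solubility, read by HPLC, using the shake flask method, measured as kinetic solubility, with a stated time of 2 h, at pH 7.4 (on this read-out higher numbers stand for higher solubility and lower numbers for lower solubility), compound 1 gives < 5000 nM, which is a limit of the assay rather than a measured number. In this assay compound 2 gives < 5000 nM, again a limit. Compound 3 stands at < 5000 nM in this assay, also a limit. Because all three values sit at the limit of < 5000 nM in this assay, at which 3 of the 3 values shown sit, the steps between them cannot be read: a step that the two limits leave unreadable from compound 1 to compound 2, a step that the two limits leave unreadable from compound 1 to compound 3 and a step that the two limits leave unreadable from compound 2 to compound 3.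

Compound 4 `Cc1cc(NCc2ccccn2)n2ncc(-c3ccncc3)c2n1` is not yet measured. It differs from compound 3 by pyridin-4-yl in place of 2,6-dimethylphenyl on an aromatic carbon. For the measured compounds named here, none of the measured steps gives a readable size for a change of this kind, and none of them involves the group that enters. Going by the values given here, their only bearing is that compound 3 stands at a limit, so the starting point itself is open. Compound 4 is therefore expected to show a step of an at least 1.6-fold higher number from compound 3 to compound 4 (0.20 log units; that floor lies within the scatter) in this assay, with wide uncertainty and a fair chance that only a limit is reported again. The estimate for compound 4 in this assay is 8000 nM, expected to lie between 2000 nM and 40000 nM.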

Compound 4, solubility: 161000 nM
Compound 4: middle estimate off by 20-fold (1.30 log units), on the low side, and the stated range ends below it.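

For the compounds shown here, on the aromatic carbon of the five-membered ring, pyridin-4-yl is the only aryl group here that gives a number clear of the limit in this assay: in place of 2,6-dimethylphenyl it gives an at least 32-fold higher number from compound 3 to compound 4 (1.50 log units; beyond the scatter), in place of 2-methylphenyl it gives an at least 32-fold higher number from compound 2 to compound 4 (1.50 log units; beyond the scatter), and in place of 4-methoxyphenyl it gives an at least 32-fold higher number from compound 1 to compound 4 (1.50 log units; beyond the scatter). Going by these compounds alone, the read-out at this position can therefore differ widely, which the earlier compounds could not show: the methyl and methoxy variants all stay at the limit, while the group with one hetero atom in its ring does not. These step sizes are floors rather than measured distances, and the steps among compound 1, compound 2 and compound 3 cannot be read: the limit of < 5000 nM in this assay, at which 3 of the 4 values shown sit.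

On these data alone, it remains open whether the large step goes with the ring nitrogen itself or simply with the absence of substituents on the aryl ring. An unsubstituted phenyl group would separate those two readings, and pyridin-3-yl would show whether the place of the nitrogen in the ring matters.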